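From chloro to methyl: what happens to compound 2?

This account rests on a few compounds, and the source may have more. Where it says the series, first, only, none or still open, it means among the compounds named here.

- Compound 1 `O=C(O)CCC/C=C\C[C@H]1/C(=N/OC(c2ccccc2)c2ccccc2)CC[C@@H]1NS(=O)(=O)c1ccc(Cl)cc1`: 17000 nM
- Compound 2 `O=C(O)CCC/C=C\C[C@H]1/C(=N/OCc2ccc(C(F)(F)F)cc2)CC[C@@H]1NS(=O)(=O)c1ccc(Cl)cc1`: 200 nM
- Compound 3 `O=C(O)CCC/C=C\C[C@H]1C(=O)CC[C@@H]1NS(=O)(=O)c1ccc(Cl)cc1`: 640 nM

All three numbers come from a functional assay (plasma) for inhibition, with Homo sapiens as the target; a higher number here means a weaker inhibitor, a lower number a stronger inhibitor. Compound 2 stands lowest at 200 nM, which makes it the strongest inhibitor of the three. Compound 3 gives 640 nM and compound 1 gives 17000 nM, and both lie beyond the usual scatter from compound 2.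

Compound 4 `Cc1ccc(S(=O)(=O)N[C@H]2CC/C(=N\OCc3ccc(C(F)(F)F)cc3)[C@@H]2C/C=C\CCCC(=O)O)cc1` has not yet been measured. It matches compound 2 except for one group: methyl in place of chloro on an aromatic carbon. This puts methyl in place of chloro on an aromatic carbon, para to a large group, so 4-chlorophenyl becomes 4-methylphenyl.

Going by the values given here, no two measured compounds differ in one place only, so the data hold no direct measure of this swap. The expectation therefore starts from compound 2 at 200 nM and foresees no step beyond the scatter in this assay, with a slight lean toward a higher number, meaning a weaker inhibitor. The expected change is a 1.3-fold higher number from compound 2 to compound 4 (0.11 log units; within the scatter). For compound 4 the estimated value is 260 nM, with an expected range from 90 nM to 750 nM.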

Compound 4, half-maximal inhibitory concentration: 180 nM
Beside the measured number, compound 4's estimate is 1.4-fold (0.16 log units) above it; the range from low to high includes it.
By their numbers in this assay, from the lowest: compounds 4 and 2 (each within the scatter of the next); then compound 3; then compound 1.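

In this assay, putting methyl in place of chloro on the aromatic carbon gives a 1.1-fold lower number from compound 2 to compound 4 (0.05 log units; within the scatter), so the two compounds cannot be told apart. This is the first pair shown that differs in one place only, which makes it the first direct reading of this position. On this carbon of the six-membered aromatic ring, para to a large group, 4-chlorophenyl and 4-methylphenyl read alike in this one setting, with the rest of the molecule held as in compound 2. No measured information is available to explain why the two groups read alike.

As far as these compounds go, both groups bring a single heavy atom and no hydrogen-bond donor or acceptor, so what a methoxy group, an amine, a carboxylic acid or a longer chain such as propyl would do on this carbon stays open. Also open, from the compounds shown here alone, is whether the same swap would read alike if made on compound 1 or on compound 3, where the rest of the molecule is different.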